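The source may hold more compounds than are shown below. What is called first, only, known or untested is meant among the compounds shown, and "the series" means these compounds.

Series notes. Three compounds share the same alkyne-linked core and have been run in a functional assay on LS174T cells (Homo sapiens) for inhibition, with a stated time of 4 days, tested at 10 uM; on this read-out higher numbers stand for a stronger effect at the one concentration tested and lower numbers for a weaker effect. Compound 1 `O=C1CCCCN1c1ccc(C#Cc2c(F)cccc2F)cc1` gives 68.1% in this assay. Compound 2 `CN(C)c1cnc(C#Cc2c(F)cccc2F)cn1` gives 91.6% in this assay. Compound 3 `Fc1cccc(F)c1C#Cc1ccc2[nH]ncc2c1` gives 82.9% in this assay.

On these three numbers compound 3 stands second highest. Its nearest neighbour is compound 2, whose number lies within the usual scatter of that of compound 3, so no order between the two can be read. The furthest is compound 1, whose number lies beyond the scatter below that of compound 3.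

The next compound, compound 4 `Cn1ncc2cc(C#Cc3c(F)cccc3F)ccc21`, is not yet measured in this assay. It differs from compound 3 only by methyl in place of hydrogen on an aromatic nitrogen. Among the measured compounds shown here, no pair of measured compounds differs in a single place, so there is no measured step to lean on. A change of this size at that position, with the rest of the molecule untouched, is expected to leave the read-out in this assay where compound 3 sits, with no step beyond the scatter in either direction. The expected step is a number 0.9 percentage points lower from compound 3 to compound 4 (within the scatter). Compound 4 is accordingly estimated at 82% in this assay, with a range from 65% to 95%.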

Compound 4, a percentage reported as inhibition, at one concentration (the size of the read-out at that concentration, not a potency): 94.6%
Beside the measured number, compound 4's estimate is 12.6 percentage points below it; the range from low to high includes it.
By their numbers in this assay, from the lowest: compound 1; then compounds 3, 2 and 4 (each within the scatter of the next, the first and the last beyond it).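

In this assay, methyl in place of hydrogen on an aromatic nitrogen gives a number 11.7 percentage points higher from compound 3 to compound 4 (beyond the scatter), and this is the only single-place step among the compounds shown. The earlier compounds shown here differ from one another in more than one place, so they could not show whether this position responds to change on its own; this step shows that it does, with a single added methyl carbon and the rest of the molecule untouched. The hydrogen on that nitrogen is also not needed to retain the effect at the one concentration tested, although this read-out gives the size of the effect at that concentration and not a potency. No measurement at hand bears on why the read-out moves with this change.

Whether ethyl, a longer chain or a chain ending in an amine or a carboxylic acid on the same aromatic nitrogen would extend this step, cancel it or reverse it remains open, as hydrogen and methyl are the only two groups shown there. Among the compounds shown here, also open is whether the same methyl change would give a similar step on a different core, as the series offers only this one pair for comparison.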